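A few compounds are considered here, and "the series" means these few. Any claim that something is new, unique, unknown or untested is made for them only; others in the source may bear on it.

Compound 1 `Cc1n[nH]c(C(=O)O)c1Cc1ccc(-c2ccc(OC(F)(F)F)cc2)cc1`: 11%
Compound 2 `Cc1n[nH]c(C(=O)O)c1Cc1ccccc1Oc1ccccc1`: 9%

Both compounds were tested in an assay on isolated protein for inhibition of 2-Hydroxyacid oxidase 2 (Homo sapiens), tested at 1 uM; a higher number here means a stronger effect of the compound at the concentration tested, a lower number a weaker effect. Compound 1 gives 11% in this assay, and compound 2 gives 9%. Compound 2 thus stands at the lower of the two numbers, yet its gap to compound 1 lies within the usual scatter of this measurement, so the two cannot be told apart on this read-out, and both sit in a weak region of inhibition.

The next compound, compound 3 `Cc1n[nH]c(C(=O)O)c1Cc1ccccc1C(F)(F)F`, follows from compound 2 by a single change: trifluoromethyl in place of phenoxy on an aromatic carbon. For the measured compounds named here, no pair of measured compounds that differ in one place is available here, so the size that such a step takes in this assay is not known from the data. Since the two measured compounds lie close together and low, compound 3 is expected to stay in that same low region, and the expected step is a number 1 percentage points lower from compound 2 to compound 3 (within the scatter), that is, none beyond the scatter. Compound 3 is estimated at 8%, with a range from 0% to 20%.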

Compound 3, a percentage reported as inhibition, at one concentration (the size of the read-out at that concentration, not a potency): 13%
For compound 3 the middle estimate is 5 percentage points below the measured one; the measured number falls inside the stated range.
By their numbers in this assay, from the lowest: compounds 2, 1 and 3 (each within the scatter of the next).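

In this assay, the change from phenoxy to trifluoromethyl on an aromatic carbon of a six-membered aromatic ring of carbon only, ortho to a large group, gives a number 4 percentage points higher from compound 2 to compound 3 (within the scatter). For the compounds shown here, this is the first step that can be read, and it shows that this assay does not separate the two groups at this position. The six-membered aromatic ring of phenoxy can therefore be replaced by a group with no ring, and by one with no hydrogen-bond acceptor, without a change beyond the scatter, although a single step says nothing about other groups at this place. No measurement at hand bears on this result.

Going by these compounds, what remains open is whether any group at this position can bring a change beyond the scatter, or whether this position has little influence on the read-out at the concentration tested. An amine, a carboxylic acid or a longer chain such as n-butyl in place of trifluoromethyl would address this, and the compounds shown cannot say how any of these would behave.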